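Chloro to bromo on the 4-chlorophenyl group of compound 3

The compounds below may be only part of what the source reports. "The series", "measured", "known", "first", "only" and "open" are said of these compounds alone.

Of the compounds shown here, three sharing one core have numbers so far. In a functional assay on MCF7 cells (Homo sapiens) for inhibition, read by MTT assay, with a stated time of 48 h (on this read-out lower numbers stand for stronger inhibition and higher numbers for weaker inhibition), compound 1 (`COc1ccc(C(c2c[nH]c3ccc(Br)cc23)c2c[nH]c3ccc(Br)cc23)c(OC)c1`) gives 77500 nM, compound 2 (`Brc1ccc2[nH]cc(C(c3ccc4ccccc4c3)c3c[nH]c4ccc(Br)cc34)c2c1`) gives 7100 nM and compound 3 (`Clc1ccc(C(c2c[nH]c3ccc(Br)cc23)c2c[nH]c3ccc(Br)cc23)cc1`) gives 3500 nM. That last number is the lowest of the three. The nearest step to it is a 2.0-fold lower number from compound 2 to compound 3 (0.31 log units; beyond the scatter), modest but beyond the scatter, and the furthest is a 22-fold lower number from compound 1 to compound 3 (1.35 log units; beyond the scatter).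

Compound 4 (`Brc1ccc(C(c2c[nH]c3ccc(Br)cc23)c2c[nH]c3ccc(Br)cc23)cc1`) differs from compound 3 at one place: bromo in place of chloro on an aromatic carbon. This puts bromo in place of chloro on an aromatic carbon, para to a large group, so 4-chlorophenyl becomes 4-bromophenyl.

Among the compounds with values here, no measured step changes a halogen alone. The three available steps each exchange a whole aromatic group: an 11-fold lower number from compound 1 to compound 2 (1.04 log units; beyond the scatter) and a 22-fold lower number from compound 1 to compound 3 (1.35 log units; beyond the scatter) are large, while a 2.0-fold lower number from compound 2 to compound 3 (0.31 log units; beyond the scatter) is modest. The present change is far smaller in kind than any of these, so no step beyond the scatter is expected in this assay, and no direction is favoured. The expected step is no change at the digits printed from compound 3 to compound 4 (within the scatter). For compound 4 the estimated value is 3500 nM, with an expected range of 1500 nM to 8000 nM.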

Compound 4, half-maximal inhibitory concentration: 3200 nM
Beside the measured number, compound 4's estimate is 1.1-fold (0.04 log units) above it; the measured number falls inside the stated range.
By their numbers in this assay, from the lowest: compounds 4 and 3 (each within the scatter of the next); then compound 2; then compound 1.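

In this assay, within the data shown here, this is the first step that changes a halogen alone, and it stays within the scatter (a 1.1-fold lower number from compound 3 to compound 4 (0.04 log units; within the scatter)), so chloro and bromo on an aromatic carbon, para to a large group, are not told apart here. The 4-bromophenyl group also stands apart from the other two aromatic groups, modestly from naphthalen-2-yl (a 2.2-fold lower number from compound 2 to compound 4 (0.35 log units; beyond the scatter)) and widely from 2,4-dimethoxyphenyl (a 24-fold lower number from compound 1 to compound 4 (1.38 log units; beyond the scatter)), which matches the standing already seen for 4-chlorophenyl in compound 3. Nothing measured here bears on why the two halogens read alike.

From the compounds shown here alone, only two halogens have been compared at this place, so it remains open whether the number would hold with fluoro, a single methoxy, an amine or a carboxylic acid there. The bromo groups on the shared core stay the same in all the compounds shown, so what replacing them with hydrogen or chloro would do to the number also remains open.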